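Adding a Methyl to a Pyridyl Acrylamide Sulfonamide

A few compounds are considered here, and "the series" means these few. Any claim that something is new, unique, unknown or untested is made for them only; others in the source may bear on it.

Of the compounds shown here, three have been tested in an assay on isolated protein for inhibition of Nicotinamide phosphoribosyltransferase (Homo sapiens), read by WST assay, with stated times of 60 min, 5 min and 30 min, in the presence of a further agent that is not named here; on this read-out higher numbers stand for weaker inhibition and lower numbers for stronger inhibition. Compound 1, `O=C(/C=C/c1cccnc1)NCCCCCCc1ccc(S(=O)(=O)Nc2ccccc2)cc1`, gives 14.4 nM. Compound 2, `O=C(/C=C/c1cccnc1)NCCCc1cccc(S(=O)(=O)Nc2ccccc2)c1`, gives 235 nM. Compound 3, `O=C(/C=C/c1cccnc1)NCCCCCCc1cccc(S(=O)(=O)Nc2ccccc2)c1`, gives 10.5 nM. Compound 3 shows the lowest of the three numbers; compound 1 lies within the usual scatter of it, so no order between the two can be claimed, while compound 2 lies well beyond the scatter with a clearly higher number.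

Compound 4, `Cc1cccc(NS(=O)(=O)c2cccc(CCCCCCNC(=O)/C=C/c3cccnc3)c2)c1`, differs from compound 3 in one place: methyl in place of hydrogen on an aromatic carbon. Going by the values given here, no pair of measured compounds shows the effect of this change, so there is no direct guide. The added group is small, and the part of the structure that differed between compound 2 and compound 3 is left untouched. The step of a 1.0-fold higher number from compound 3 to compound 4 (0.02 log units; within the scatter) is therefore expected to be small, with no direction beyond the scatter. Compound 4 is expected to give about 11 nM, estimated within a range from 4 nM to 30 nM in this assay.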

Compound 4, half-maximal inhibitory concentration: 12.3 nM
For compound 4 the middle estimate is 1.1-fold (0.05 log units) below the measured one; the measured number falls inside the stated range.
By their numbers in this assay, from the lowest: compounds 3, 4 and 1 (each within the scatter of the next); then compound 2.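

In this assay, going from phenylsulfamoyl to (3-methylphenyl)sulfamoyl gives a 1.2-fold higher number from compound 3 to compound 4 (0.07 log units; within the scatter), so this carbon of the ring takes one added methyl with no change that stands out from the scatter. Going by these compounds alone, this is the first measured step on this ring, as the earlier compounds formed no pair differing in one place and so said nothing about it. Nothing at hand gives a reason for this result.

As far as these compounds go, whether the same holds for a larger group at this carbon, such as a tert-butyl, or for a different kind of group, such as an amine or a carboxylic acid, remains open. A single methyl at this one carbon also leaves the other carbons of the ring unexplored.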